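Swapping carboxy for dimethylamino on a cinnamanilide chain

This account rests on a few compounds, and the source may have more. Where it says the series, first, only, none or still open, it means among the compounds named here.

Three anilides sharing the core of compound 1, `O=C(/C=C/C(F)(F)F)Nc1ccccc1`, differ only in the group carried on the double-bonded chain carbon. In an ADME assay for pharmacokinetics, read by LC-MS, in phosphate buffer, with a stated time of 120 min, at pH 7.4, tested at 1 uM, in the presence of a further agent that is not named here (on this read-out higher numbers stand for a longer-lived compound and lower numbers for a shorter-lived compound), compound 1 gives 0.267 h. Compound 2, `C/C=C/C(=O)Nc1ccccc1`, gives only the limit of the assay, > 8.53 h. Compound 3, `O=C(O)C/C=C/C(=O)Nc1ccccc1`, likewise gives only the limit, > 8.53 h. Both an at least 31-fold higher number from compound 1 to compound 2 (1.50 log units; beyond the scatter) and an at least 31-fold higher number from compound 1 to compound 3 (1.50 log units; beyond the scatter) are large moves in the same direction, whereas a step that the two limits leave unreadable from compound 2 to compound 3 cannot be sized. Compound 3 therefore stands at the limit of > 8.53 h in this assay, at which 2 of the 3 values shown sit, with no number within it.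

Compound 4, `CN(C)C/C=C/C(=O)Nc1ccccc1`, differs from compound 3 by dimethylamino in place of carboxy on a saturated chain carbon bound to a double-bonded chain carbon. Among the measured compounds shown here, no measured step covers this exchange directly; the steps from compound 1 show only that leaving trifluoromethyl brings a large lengthening, and compound 2 and compound 3 together show two limits. Compound 4 is expected to stay long-lived, with an estimated step of an at least 1.0-fold lower number from compound 3 to compound 4 (0.02 log units; that floor lies within the scatter). Compound 4 is thus estimated at 8 h, between 2.5 h and 12 h.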

Compound 4, half-life: 1.93 h
Compound 4: the middle estimate sits 4.1-fold (0.62 log units) above what was measured, outside the stated range (below it).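

Dimethylamino on the saturated chain carbon gives the first reading below the limit among the compounds without trifluoromethyl: the exchange for carboxy brings an at least 4.4-fold lower number from compound 3 to compound 4 (0.64 log units; beyond the scatter), and the exchange for hydrogen brings an at least 4.4-fold lower number from compound 2 to compound 4 (0.64 log units; beyond the scatter). This shows that the group at this place still matters once trifluoromethyl has gone, and that losing trifluoromethyl does not by itself carry a compound to the limit. Even so, compound 4 keeps part of the gain, with a 7.2-fold higher number from compound 1 to compound 4 (0.86 log units; beyond the scatter).

On these data alone, compound 2 and compound 3 cannot be told apart, and the full size of both falls to compound 4 stays unreadable, because each of the two compounds gives only a limit: the limit of > 8.53 h in this assay, at which 2 of the 4 values shown sit. Whether methylamino or a hydroxy group at the same place would lower the half-life as far as dimethylamino does remains open.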